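Chloro for fluoro on the aryl ring of compound 3

The source may report more compounds than this note shows. Statements on the series, on what has been measured and on what is new or still open speak of the compounds shown alone.

Compound 1 `CC(C)(C)n1ncc(OCc2nnc(-c3ccc(Br)cc3)o2)c(Cl)c1=O` gives 21.4 ug/mL in a functional assay on the whole organism for inhibition, with Mythimna separata as the target, with a stated time of 5 days; on this read-out higher numbers stand for an effect only at larger amounts of compound and lower numbers for an effect already at smaller amounts. Compound 2 `Cc1cc(C)cc(-c2nnc(COc3cnn(C(C)(C)C)c(=O)c3Cl)o2)c1` reaches only the limit > 300 ug/mL in this assay. Compound 3 `CC(C)(C)n1ncc(OCc2nnc(-c3ccc(Cl)cc3F)o2)c(Cl)c1=O` gives 10.4 ug/mL in this assay.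

Among the two numbers measured, compound 3 stands lowest; the step from compound 1 is a 2.1-fold lower number from compound 1 to compound 3 (0.31 log units; beyond the scatter). The swap of the whole aryl group gives an at least 14-fold higher number from compound 1 to compound 2 (1.14 log units; beyond the scatter) and an at least 28-fold lower number from compound 2 to compound 3 (1.46 log units; beyond the scatter), the latter starting from a limit (the limit of > 300 ug/mL in this assay, at which 1 of the 3 values shown sits).

Compound 4 `CC(C)(C)n1ncc(OCc2nnc(-c3ccc(Cl)cc3Cl)o2)c(Cl)c1=O` differs from compound 3 by chloro in place of fluoro on an aromatic carbon. Going by the values given here, no measured step changes this single halogen; the measured steps exchange the entire aryl group and so bear only loosely on it. Compound 1 and compound 3 show that two halogen-bearing aryl groups sit within a modest span of each other, and compound 4 is expected to stay in that span, with a step of a 1.2-fold higher number from compound 3 to compound 4 (0.06 log units; within the scatter) not clearly beyond the scatter. Compound 4 is estimated at 12 ug/mL, with a range from 4 ug/mL to 40 ug/mL.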

Compound 4, half-maximal effective concentration: 27.8 ug/mL
Beside the measured number, compound 4's estimate is 2.3-fold (0.36 log units) below it, within the range that was stated.
By their numbers in this assay, from the lowest: compound 3; then compounds 1 and 4 (each within the scatter of the next). At a limit, above all of these: compound 2.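

Going by these compounds alone, on the aromatic carbon ortho to a large group, the single exchange of chloro for fluoro gives in this assay a 2.7-fold higher number from compound 3 to compound 4 (0.43 log units; beyond the scatter), so the two halogens are not interchangeable at this position, a point the earlier whole-aryl exchanges could not isolate. The 2,4-dichlorophenyl group does not separate from the 4-bromophenyl group, with a 1.3-fold higher number from compound 1 to compound 4 (0.11 log units; within the scatter), so a second halogen on the ring does not by itself set the number apart from that of the singly substituted ring. The 3,5-dimethylphenyl group stays apart, with an at least 10-fold lower number from compound 2 to compound 4 (1.03 log units; beyond the scatter), a step read from a limit: the limit of > 300 ug/mL in this assay, at which 1 of the 4 values shown sits.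

The compounds shown leave open what a methoxy group or an amine on this carbon would give. They also leave open whether the step from fluoro to chloro keeps its size when the chloro group meta to it is replaced by bromo.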